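The source may hold more compounds than are shown below. What is called first, only, known or untested is meant among the compounds shown, and "the series" means these compounds.

Compound 1 `Cc1cc(=O)c2c(O)cc(OCc3ccccc3Br)c([C@H]3CCN(C)C[C@H]3O)c2o1` gives 3%
Compound 2 `CCN(CC)Cc1c(O)c([C@H]2CCN(C)C[C@H]2O)c2oc(C)cc(=O)c2c1O` gives 47%
Compound 3 `Cc1oc2c([C@H]3CCN(C)C[C@H]3O)c(O)cc(O)c2c(=O)c1C(O)c1cccc(Cl)c1` gives 22%

All three numbers come from a functional assay on HL-60 cells (Homo sapiens) for inhibition, read by MTT assay, with a stated time of 48 h, tested at 10 uM (a lower number here means less inhibition of growth, a higher number more inhibition of growth at the concentration tested), and the spread among them is wide. Compound 3 stands second highest of the three. Its number lies beyond the usual scatter above that of compound 1 and beyond the scatter below that of compound 2.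

The next compound to be tested is compound 4 `CCOc1ccc(Br)c(C(O)c2c(C)oc3c([C@H]4CCN(C)C[C@H]4O)c(O)cc(O)c3c2=O)c1` which differs from compound 3 in one place. On a saturated chain carbon bound to an aromatic carbon and an oxygen on a saturated carbon, 2-bromo-5-ethoxyphenyl stands in place of 3-chlorophenyl 2-bromo-5-ethoxyphenyl in place of 3-chlorophenyl on a saturated chain carbon bound to an aromatic carbon and an oxygen on a saturated carbon and both groups carry no net charge.

Going by the values given here, no two measured compounds differ in only one place, so nothing yet shows what a single swap of this kind does in this assay. With no evidence pointing either way, the expectation is no step beyond the scatter, in neither direction. Starting from compound 3 at 22% the expected change is small, namely a number 2 percentage points lower from compound 3 to compound 4 (within the scatter) and it is an uncertain guess. For compound 4 the estimated value is 20%, with an expected range from 4% to 40%.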

Compound 4, percent growth inhibition at one concentration: 2%
Compound 4: the middle estimate sits 18 percentage points above what was measured; measured number outside the range, below it.
By their numbers in this assay, from the lowest: compounds 4 and 1 (each within the scatter of the next); then compound 3; then compound 2.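

Going by these compounds alone, this is the first single swap at this place, on a saturated chain carbon bound to an aromatic carbon and an oxygen on a saturated carbon, and it shows that the group held there matters in this assay. Putting 2-bromo-5-ethoxyphenyl in place of 3-chlorophenyl gives a number 20 percentage points lower from compound 3 to compound 4 (beyond the scatter), so the growth inhibition seen with compound 3 does not survive this change of ring group at the concentration tested. The swap alters several things at once: bromine stands in place of chlorine, the heavy-atom count of the group rises, and the entering group adds an oxygen and a hydrogen-bond acceptor that the leaving group lacks.

Nothing measured here explains why the number falls.

Which of these changes carries the step stays open, and a plain phenyl, or a phenyl ring bearing only the bromine or only the ethoxy group, would help to separate them. Also open, as far as these compounds go, is how a ring carrying an amine or a carboxylic acid would behave at this place.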